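Bromo on the benzoyl ring: next step in the series

This account rests on a few compounds, and the source may have more. Where it says the series, first, only, none or still open, it means among the compounds named here.

Measured so far in a functional assay on Ehrlich cells (Mus musculus) for cytotoxicity, read by trypan blue exclusion, with a stated time of 48 h; a higher number here means a weaker inhibitor, a lower number a stronger inhibitor:

Compound 1, `Cc1cc(C(=O)c2ccccc2)ccc1OCC(=O)Nc1nc(-c2ccccc2)cs1`: 22300 nM
Compound 2, `COc1ccc(-c2csc(NC(=O)COc3ccc(C(=O)c4ccccc4)cc3C)n2)cc1`: 27100 nM
Compound 3, `Cc1cc(C(=O)c2ccccc2)cc(C)c1OCC(=O)Nc1nc(-c2ccccc2)cs1`: 22100 nM

Compound 2 gives the highest number of the three in this assay, but its gaps to compound 1 and to compound 3 are both within the scatter, so no order among the three can be read from these numbers.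

The step under consideration goes from compound 2 to compound 4, `COc1ccc(-c2csc(NC(=O)COc3ccc(C(=O)c4cccc(Br)c4)cc3C)n2)cc1`. The change is bromo in place of hydrogen on an aromatic carbon.

Two measured steps are of the same kind, a hydrogen on an aromatic carbon replaced by a small group, though on a different ring of the shared core: a 1.2-fold higher number from compound 1 to compound 2 (0.08 log units; within the scatter) and a 1.0-fold lower number from compound 1 to compound 3 (0.00 log units; within the scatter). Neither moved the number beyond the scatter. Among the compounds with values here, no measured step touches the benzoyl ring itself, and nothing shows what a bromo does there, so the analogy is loose.

On that basis the expectation for compound 4 in this assay is no step beyond the scatter, a 1.1-fold lower number from compound 2 to compound 4 (0.04 log units; within the scatter), with the range kept wide for the untested ring. The estimate for compound 4 is 25000 nM, between 11000 nM and 55000 nM.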

Compound 4, half-maximal inhibitory concentration: 38100 nM
Beside the measured number, compound 4's estimate is 1.5-fold (0.18 log units) below it, within the range that was stated.
By their numbers in this assay, from the lowest: compounds 3, 1, 2 and 4 (each within the scatter of the next).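

Within the data shown here, this is the first substitution on the benzoyl ring, and in this assay the change to a 3-bromophenyl gives a 1.4-fold higher number from compound 2 to compound 4 (0.15 log units; within the scatter). This aromatic carbon, meta to a large group, therefore accepts a single bromine atom without a step beyond the scatter, so the benzoyl ring now matches the other ring of the shared core, where the methoxy and methyl steps also stayed within the scatter, and no listed step in the series goes against this. No evidence is available that bears on the size of this step or on what lies behind it.

The compounds shown leave open whether a different group on this same carbon, such as an amine, a carboxylic acid or a longer alkyl chain, would produce a step beyond the scatter, or whether this position stays as flat for groups unlike bromo. They also leave open whether bromo would give a similar step on the other carbons of the benzoyl ring, or on the core of compound 1 or compound 3, where the methoxy of compound 2 is absent.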